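Swapping a Pyridine Ester for Chlorophenyl on a Shared Core

The compounds below may be only part of what the source reports. "The series", "measured", "known", "first", "only" and "open" are said of these compounds alone.

Of the compounds shown here, three built on a shared core have been measured in an ADME assay on PBMC cells (Homo sapiens) for cytotoxicity; a lower number here means that less compound is tolerated, a higher number that more compound is tolerated. Compound 1 `CCO/N=C(/c1ccc(Br)cc1)C1CCN(C(C)CCNC(=O)c2c(Cl)cncc2Cl)CC1` gives 33800 nM, compound 2 `COC(=O)c1cccc(OC(c2ccc(C(F)(F)F)cc2)C2CCN(C(C)CCNC(=O)c3c(Cl)cncc3Cl)CC2)n1` gives 14600 nM, and compound 3 `CC(CCNC(=O)c1c(Cl)cncc1Cl)N1CCC(C(O)c2ccc(Br)cc2)CC1` gives 198000 nM. Compound 2 stands at the lowest of the three numbers, so it is the least tolerated: compound 1 lies higher by a gap beyond the scatter, and compound 3 lies higher still, well beyond the scatter. Compound 4 `CC(CCNC(=O)c1c(Cl)cncc1Cl)N1CCC(C(Oc2ccccc2Cl)c2ccc(C(F)(F)F)cc2)CC1` has not yet been measured in this assay. It differs from compound 2 in one place, 2-chlorophenyl in place of 6-(methoxycarbonyl)pyridin-2-yl on an oxygen on a saturated carbon: a 2-chlorophenyl group enters where the 6-(methoxycarbonyl)pyridin-2-yl group leaves, on the oxygen on a saturated carbon whose other neighbours are a saturated chain carbon. Among the compounds with values here, no measured pair shows the effect of this kind of change, so the expectation rests on the spread of the three numbers alone. For compound 4 the step of a 1.1-fold higher number from compound 2 to compound 4 (0.04 log units; within the scatter) is expected to stay within the scatter, with no clear direction. Compound 4 is therefore estimated at 16000 nM, in a range from 5000 nM to 50000 nM.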

Compound 4, half-maximal cytotoxic concentration: 4400 nM
Compound 4: the middle estimate sits 3.6-fold (0.56 log units) above what was measured; the measured number lies below the stated range.
By their numbers in this assay, from the lowest: compound 4; then compound 2; then compound 1; then compound 3.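

Within the data shown here, this pair is the first to isolate a single change, and in this assay the swap gives a 3.3-fold lower number from compound 2 to compound 4 (0.52 log units; beyond the scatter), showing that the group on this oxygen can shift how much compound the cells tolerate. The step changes several features at once: the group that leaves brings a ring nitrogen, a methoxycarbonyl group and hydrogen-bond acceptors, while the group that enters has a carbon-only ring, a chlorine and no acceptors. Nothing available explains the lower number.

As far as these compounds go, it remains open whether the step follows the added chlorine, the lost ring nitrogen or the lost methoxycarbonyl group. The compounds shown also do not reveal where a plain phenyl group, or a pyridine bearing a carboxylic acid in place of the methoxycarbonyl group, would fall in this assay.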